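A few compounds are considered here, and "the series" means these few. Any claim that something is new, unique, unknown or untested is made for them only; others in the source may bear on it.

Measured compounds, with their solubility in a physicochemical assay for solubility, with a stated time of 18 h, at pH 7.4; on this read-out lower numbers stand for lower solubility and higher numbers for higher solubility:
- compound 1 `c1ccc(Oc2ccc3c(NCCCNCc4ccco4)ccnc3c2)cc1`: 14500 nM
- compound 2 `CC(C)(C)c1ccc(-c2ccc3c(NCCCNCc4ccco4)ccnc3c2)cc1`: 32000 nM
- compound 3 `c1coc(CNCCCNc2ccnc3cc(CC4CCCCC4)ccc23)c1`: 4200 nM

Compound 1 stands second highest of the three. Compound 2 lies above it by a 2.2-fold higher number from compound 1 to compound 2 (0.34 log units; beyond the scatter), and compound 3 below it by a 3.5-fold lower number from compound 1 to compound 3 (0.54 log units; beyond the scatter); the two outer compounds are separated by a 7.6-fold lower number from compound 2 to compound 3 (0.88 log units; beyond the scatter). All three steps are beyond the scatter, and all three concern the group on the aromatic carbon of the shared core, while the (furan-2-yl)methyl on the amine is kept throughout.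

Compound 4 `COc1ccc(F)cc1CNCCCNc1ccnc2cc(Oc3ccccc3)ccc12` keeps the phenoxy of compound 1 and changes the other end: 5-fluoro-2-methoxyphenyl in place of furan-2-yl on a saturated chain carbon bound to an amine nitrogen.

Among the compounds with values here, no measured step touches this position, so the three steps set only the scale of what single-group changes have done here, which is modest in every case. For the step from compound 1 to compound 4 in this assay a modest change, more likely downward than upward, is therefore expected, without a measured precedent for the direction.

Compound 4 is estimated at 8000 nM, within 3000 nM to 22000 nM, which means an expected step of a 1.8-fold lower number from compound 1 to compound 4 (0.26 log units; within the scatter).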

Compound 4, solubility: 14500 nM
For compound 4 the middle estimate is 1.8-fold (0.26 log units) below the measured one, within the range that was stated.
By their numbers in this assay, from the lowest: compound 3; then compounds 1 and 4 (each within the scatter of the next); then compound 2.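

In this assay, within the data shown here, the only measured change on a saturated chain carbon bound to an amine nitrogen gives a step within the scatter (no change at the digits printed from compound 1 to compound 4 (within the scatter)), with the phenoxy of compound 1 held in place. The earlier steps shown here, all at the group on the aromatic carbon, each lay beyond the scatter, whereas here 5-fluoro-2-methoxyphenyl, with 9 heavy atoms, stands in place of furan-2-yl, with 5, and the read-out does not move. This position therefore tolerates a swap of one aromatic ring for another in this assay, at least for this pair, and nothing measured here offers an explanation for that.

This single pair leaves open whether the same holds when the group on the aromatic carbon is the 4-(tert-butyl)phenyl of compound 2 or the cyclohexylmethyl of compound 3. Also open, going by these compounds, is how this assay would read with a non-aromatic group at this position, such as a morpholine or a carboxylic acid in place of furan-2-yl, or with a longer chain carrying the ring.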